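Mirror-image switch at the ring carbon of compound 3

The compounds below may be only part of what the source reports. "The series", "measured", "known", "first", "only" and "open" are said of these compounds alone.

Of the compounds shown here, three that share one core have been tested so far in a functional assay on MCF7 cells (Homo sapiens) for inhibition; a lower number here means a stronger inhibitor, a higher number a weaker inhibitor. Compound 1 `COc1c(C)cnc(CN2c3nc(N)nc(Cl)c3NC(=O)[C@@H]2C(C)C)c1C` carries an isopropyl group on a saturated ring carbon and gives 1600 nM. Compound 2 `COc1c(C)cnc(CN2c3nc(N)nc(Cl)c3NC(=O)[C@@H]2CC(C)C)c1C` has an isobutyl group at that carbon instead and gives 930 nM; the change a 1.7-fold lower number from compound 1 to compound 2 (0.24 log units; within the scatter) is small. Compound 3 `COc1c(C)cnc(CN2c3nc(N)nc(Cl)c3NC(=O)[C@H]2C)c1C` carries a methyl group there and gives 790 nM, the lowest number of the three; its gap to compound 2 is within the scatter, while its gap to compound 1 is beyond it.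

Compound 4 `COc1c(C)cnc(CN2c3nc(N)nc(Cl)c3NC(=O)[C@@H]2C)c1C` is built from compound 3 by a single change: the two compounds have the same atoms and bonds and differ only in configuration as drawn: 1 of 1 stereo elements differ; a stereocentre at a saturated ring carbon is drawn R in compound 3 and S in compound 4. The two compounds are mirror images of each other at that carbon. Going by the values given here, none of the measured steps bears on this change, since every measured step altered the size of the group on the ring carbon, not its spatial arrangement, and no pair of mirror-image compounds has been measured. The direction of any step in this assay therefore cannot be read from the data, and the estimate stays wide.

The number expected for compound 4 in this assay is 1200 nM, in the range 250 nM to 6000 nM, which corresponds to an expected step of a 1.5-fold higher number from compound 3 to compound 4 (0.18 log units; within the scatter).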

Compound 4, half-maximal inhibitory concentration: 940 nM
Compound 4: the middle estimate sits 1.3-fold (0.11 log units) above what was measured; measured number inside the range.
By their numbers in this assay, from the lowest: compounds 3, 2, 4 and 1 (each within the scatter of the next, the first and the last beyond it).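

Going by these compounds alone, the first mirror-image pair shows that, in this assay, switching the ring carbon that carries the methyl group from R to S barely moves the number (a 1.2-fold higher number from compound 3 to compound 4 (0.08 log units; within the scatter)). Within the data shown here, this pair gives the cleanest reading of the spatial arrangement at this position so far, with no change of group to blur the comparison, and only one thing can account for the small step: the fact that compounds 3 and 4 differ only in the configuration as drawn. The steps to compound 4 from the isobutyl and isopropyl compounds also stay within the scatter (a 1.0-fold higher number from compound 2 to compound 4 (0.00 log units; within the scatter); a 1.7-fold lower number from compound 1 to compound 4 (0.23 log units; within the scatter)), so the mirror-image switch does not set compound 4 apart from either of them.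

Isopropyl and isobutyl each appear here in a single configuration, so it remains open whether the switch would stay just as small with one of those groups on the ring carbon. Also open, on these data alone, is how an amine, a carboxylic acid or a phenyl ring at this carbon would read in this assay, and whether the two mirror-image forms would then separate.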